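Solubility of Three Chain-Lengthened Analogues

The source may report more compounds than this note shows. Statements on the series, on what has been measured and on what is new or still open speak of the compounds shown alone.

Compound 1, `CCCCCCCC[S+]([O-])CCC(=O)NC(CO)(CO)CO`, in an ADME assay for solubility (a lower number here means a less soluble compound, a higher number a more soluble compound), gives > 10000 ug/mL, a limit of the assay rather than a number.
Compound 2, `CCCCCCCCCC[S+]([O-])CCC(=O)NC(CO)(CO)CO`, in this assay gives > 10000 ug/mL, likewise a limit and not a number.

The step from the first to the second, a step that the two limits leave unreadable from compound 1 to compound 2, cannot be read because both ends sit at the limit; compound 2 therefore stands only at the limit of > 10000 ug/mL in this assay, at which 2 of the 2 values shown sit, with no number of its own. The next compound, compound 3, `CCCCCCCCCCCC[S+]([O-])CCC(=O)NC(CO)(CO)CO`, differs from compound 2 by ethyl in place of hydrogen on a saturated chain carbon, ten or more bonds along the chain from a sulfur. Among the measured compounds shown here, the one measured step that bears on this change gave no readable size, so nothing among the measurements shows a drop below the limit, yet nothing rules one out either. On that footing the step is expected to be a number no higher from compound 2 to compound 3 (the limit leaves the size open). In this assay compound 3 is thus expected to give about 10000 ug/mL, within 2500 ug/mL to 40000 ug/mL, most likely again reported as a limit.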

Compound 3, solubility: > 6000 ug/mL
Compound 3 gave a limit, no number; the forecaster's own chance of this, stated with the estimate: 60%; the middle value does not contradict the limit.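

In this assay compound 3 gives > 6000 ug/mL, a limit and not a number. Among the compounds shown here, no step among compound 1, compound 2 and compound 3 can be read. The compounds shown leave open what number each would give, and whether the longer chains make any difference to it.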